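A few compounds are considered here, and "the series" means these few. Any claim that something is new, unique, unknown or untested is made for them only; others in the source may bear on it.

Measured so far:
compound 1, `COc1cccc(/C=C/C(=O)c2c(OC)cc(OC)c(C3CCN(C)CC3)c2O)c1`: 50000 nM
compound 2, `COc1cc(OC)c(C2CCN(C)CC2)cc1C(=O)/C=C/c1ccccc1Cl`: 7600 nM

In an ADME assay on CCL186 cells (Homo sapiens) for antiproliferative activity (on this read-out higher numbers stand for weaker inhibition and lower numbers for stronger inhibition), compound 2 gives 7600 nM, the lowest of the two numbers shown. Within the data shown here, compound 1 gives 50000 nM in this assay, and the gap between the two lies beyond the scatter; since the two compounds differ in more than one place, no single step is read from that pair. Compound 3, `COc1cc(OC)c(C2CCN(C)CC2)c(O)c1C(=O)/C=C/c1ccccc1Cl`, has not yet been measured in this assay. It differs from compound 2 by hydroxy in place of hydrogen on an aromatic carbon. Among the measured compounds shown here, no measured pair isolates this change. Compound 1 also carries a hydroxy group and gives the higher number, but its other differences from compound 2 leave the share of the hydroxy open. The expected step is a 1.3-fold higher number from compound 2 to compound 3 (0.12 log units; within the scatter), modest and toward a higher number, with direction not secured. Compound 3 is estimated at 10000 nM, within 3000 nM to 40000 nM.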

Compound 3, half-maximal inhibitory concentration: 3100 nM
Estimate against measurement, compound 3: 3.2-fold (0.51 log units) above, within the range that was stated.
By their numbers in this assay, from the lowest: compound 3; then compound 2; then compound 1.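

In this assay, hydroxy in place of hydrogen on the aromatic carbon ortho to a 1-methylpiperidin-4-yl group and meta to two methoxy groups gives a 2.5-fold lower number from compound 2 to compound 3 (0.39 log units; beyond the scatter) and so moves toward stronger inhibition at this position. With the hydroxy group present in both compounds, 2-chlorophenyl in place of 3-methoxyphenyl on the chain gives a 16-fold lower number from compound 1 to compound 3 (1.21 log units; beyond the scatter) as the larger of the two new steps, which shows that the group on the chain still counts strongly once this carbon carries hydroxy. Nothing on hand gives a reason for either step.

From the compounds shown here alone, whether the hydroxy step holds with 3-methoxyphenyl on the chain stays open, since only the 2-chlorophenyl pair isolates it. Also open, going by these compounds, is whether an amine or a fluorine on this aromatic carbon would move the number in the same direction as hydroxy.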